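Swapping a Halogenated Ring on a Hydrazide Arm

The source may report more compounds than this note shows. Statements on the series, on what has been measured and on what is new or still open speak of the compounds shown alone.

Compound 1 `O=C(N/N=C/c1c(-c2cc3ccccc3oc2=O)[nH]c2ccccc12)c1ccccc1F` and compound 2 `O=C(N/N=C/c1c(-c2cc3ccc(Br)cc3oc2=O)[nH]c2ccccc12)c1ccc(Cl)cc1` were both tested in a toxicity assay on Vero cells (Chlorocebus sabaeus) for inhibition, read by MTT assay, with a stated time of 48 h; on this read-out higher numbers stand for weaker inhibition and lower numbers for stronger inhibition. Compound 2 gives 71400 nM, the only true number shown. Compound 1 reaches the assay's limit and is recorded as > 200000 nM, which is a limit rather than a number, as the limit of > 200000 nM in this assay, at which 1 of the 2 values shown sits, notes. Going by these compounds, compound 3 `O=C(N/N=C/c1c(-c2cc3ccc(Br)cc3oc2=O)[nH]c2ccccc12)c1ccccc1F` is untested and differs from compound 2 by 2-fluorophenyl in place of 4-chlorophenyl on a carbonyl carbon. Compound 1 carries this same 2-fluorophenyl. The step of a 2.1-fold higher number from compound 2 to compound 3 (0.32 log units; beyond the scatter) is therefore expected to point toward weaker inhibition, beyond the scatter. Compound 3 is estimated at 150000 nM, between 60000 nM and 300000 nM.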

Compound 3, half-maximal inhibitory concentration: > 200000 nM
Compound 3: a limit, no number; the forecaster's own chance of this, stated with the estimate: 45%; middle value at least 1.3-fold (0.12 log units) from the limit.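

In this assay, among the compounds shown here, 2-fluorophenyl in place of 4-chlorophenyl on a carbonyl carbon gives an at least 2.8-fold higher number from compound 2 to compound 3 (0.44 log units; beyond the scatter), the first single-place change here with a readable step. The value of compound 3 is a limit, not a number. The step for bromo in place of hydrogen on an aromatic carbon cannot be read, because both values are limits: the limit of > 200000 nM in this assay, at which 2 of the 3 values shown sit.

Still open, going by these compounds, is whether the step follows the change of halogen or its place on the ring. Also open, on these data alone, is how an amine in place of the halogen would read.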